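The compounds below may be only part of what the source reports. "The series", "measured", "known", "first", "only" and "open" are said of these compounds alone.

In a physicochemical assay for solubility, in phosphate buffer, at pH 7.4 (on this read-out lower numbers stand for lower solubility and higher numbers for higher solubility), compound 1 `CCOC(=O)c1c(-c2ccccc2)[nH]c2cccc(OC)c2c1=O` reads > 100000 nM, a limit and not a number. Going by these compounds, compound 2 `CCOC(=O)c1c(-c2ccccc2C)[nH]c2cccc(OC)c2c1=O` reads > 100000 nM, likewise a limit, so its true position is unknown. Among the compounds with values here, compound 3 `CCOC(=O)c1c(-c2cccc(Cl)c2)[nH]c2cc(OC)ccc2c1=O` gives 58000 nM, but it differs from both in more than one place and supplies no step.

Compound 4 `CCOC(=O)c1c(-c2cccc(C)c2)[nH]c2cccc(OC)c2c1=O` carries 3-methylphenyl in place of 2-methylphenyl on an aromatic carbon. Within the data shown here, the one measured step bearing on this change is a step that the two limits leave unreadable from compound 1 to compound 2, which offers no size to carry over. No shift beyond the scatter is therefore expected in this assay, in either direction, and another limit is quite possible. The expected change is a number no higher from compound 2 to compound 4 (the limit leaves the size open). For compound 4 the estimated value is 100000 nM, with an expected range of 50000 nM to 200000 nM.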

Compound 4, solubility: > 100000 nM
Compound 4 gave a limit, no number; the forecaster's own chance of this, stated with the estimate: 65%; the middle value sits exactly at the limit.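

Within the data shown here, compound 1, compound 2 and compound 4 all read as limits, not numbers, in this assay, so no step among them can be read. Whether 2-methylphenyl and 3-methylphenyl differ at all in true solubility stays open: the limit of > 100000 nM in this assay, at which 3 of the 4 values shown sit.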